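The compounds below may be only part of what the source reports. "The series", "measured", "known", "first", "only" and "open" are said of these compounds alone.

Measured compounds in the series:

- Compound 1, `CC(=O)Oc1ccccc1C(=O)O[C@H]1CO[C@H]2[C@@H]1OC[C@H]2OC(=O)c1ccc(O)cc1`: 0.0198 h
- Compound 2, `COc1ccccc1C(=O)O[C@@H]1CO[C@H]2[C@@H]1OC[C@@H]2OC(=O)c1ccccc1OC(C)=O`: 0.0578 h

Both numbers come from an ADME assay on a cell-free system (plasma, Homo sapiens) for metabolic stability, with Plasma (Rattus norvegicus) as the target, read by HPLC, at pH 7.4; on this read-out lower numbers stand for a shorter-lived compound and higher numbers for a longer-lived compound. Compound 2 stands highest of the two numbers; its nearest neighbour is compound 1, and the step of a 2.9-fold higher number from compound 1 to compound 2 (0.47 log units; beyond the scatter) lies beyond the scatter. That step exchanges 4-hydroxyphenyl for 2-methoxyphenyl on a carbonyl carbon.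

The unmeasured compound 3, `COc1ccc(C(=O)O[C@@H]2CO[C@H]3[C@@H]2OC[C@@H]3OC(=O)c2ccccc2OC(C)=O)cc1`, differs from compound 2 by 4-methoxyphenyl in place of 2-methoxyphenyl on a carbonyl carbon. Going by the values given here, no measured step in this assay moves a methoxy group between two positions on the phenyl ring; the one step at hand, compound 1 to compound 2, changes both the substituent and its position at once, so it bears on compound 3 only loosely. With nothing that separates the two methoxyphenyl groups, the expectation for compound 3 is a step of a 1.3-fold lower number from compound 2 to compound 3 (0.11 log units; within the scatter) from compound 2, within the scatter and of no settled direction. Compound 3 is therefore estimated at 0.045 h in this assay, with a range from 0.015 h to 0.13 h.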

Compound 3, half-life: 0.0525 h
Estimate against measurement, compound 3: 1.2-fold (0.07 log units) below, and the stated range covers the measured number.
By their numbers in this assay, from the lowest: compound 1; then compounds 3 and 2 (each within the scatter of the next).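

In this assay, 4-methoxyphenyl in place of 2-methoxyphenyl on a carbonyl carbon gives a 1.1-fold lower number from compound 2 to compound 3 (0.04 log units; within the scatter) and so does not separate the two methoxyphenyl groups in this series. The earlier step changed the substituent and its position together, whereas methyl in place of hydrogen on the oxygen on the aromatic ring now isolates the substituent change and gives a 2.7-fold higher number from compound 1 to compound 3 (0.42 log units; beyond the scatter) with the position unchanged. Among these three compounds, the hydroxy compound, compound 1, thus stands apart from the two methoxy compounds, but nothing at hand gives a reason for either step.

A 2-hydroxyphenyl group would show whether the hydroxy result holds at the other ring position named here, and an amine, a carboxylic acid or a longer chain such as ethoxy in place of methoxy would show how far the half-life follows the group on this ring. On these data alone, the effect of changing the acetoxy-bearing ester common to all three compounds also remains open, so these notes cannot yet say how much of the short half-life rests on that part of the structure.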